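Trimming the methyl of compound 2 down to hydrogen

The compounds below may be only part of what the source reports. "The series", "measured", "known", "first", "only" and "open" are said of these compounds alone.

Compound 1 `COc1ccc(/C=C/C(=O)Nc2nc(-c3c(C)cc(C)cc3C)cs2)cc1`: 4160 nM
Compound 2 `Cc1ccc(/C=C/C(=O)Nc2nc(-c3c(C)cc(C)cc3C)cs2)cc1`: 7880 nM

In a functional assay on K562 cells (Homo sapiens) for inhibition, read by MTT assay, with a stated time of 96 h (on this read-out higher numbers stand for weaker inhibition and lower numbers for stronger inhibition), compound 1 gives 4160 nM and compound 2 gives 7880 nM. Among the measured compounds shown here, compound 2 stands at the upper end of these two numbers, but the only step between them, a 1.9-fold higher number from compound 1 to compound 2 (0.28 log units; within the scatter), is within the scatter. Compound 3 `Cc1cc(C)c(-c2csc(NC(=O)/C=C/c3ccccc3)n2)c(C)c1` carries the difference (hydrogen in place of methyl on an aromatic carbon), which cut one bond further out reads 4-methylphenyl to phenyl. For the measured compounds named here, the one measured step at this carbon, a 1.9-fold higher number from compound 1 to compound 2 (0.28 log units; within the scatter), is within the scatter, so no step beyond the scatter is expected for a 1.0-fold higher number from compound 2 to compound 3 (0.01 log units; within the scatter). Compound 3 is therefore estimated at 8000 nM, within 3000 nM to 25000 nM.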

Compound 3, half-maximal inhibitory concentration: 40400 nM
For compound 3 the middle estimate is 5.1-fold (0.70 log units) below the measured one; measured number above the stated range.
By their numbers in this assay, from the lowest: compounds 1 and 2 (each within the scatter of the next); then compound 3.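

The aromatic carbon para to a large group proved sensitive after all: methyl and methoxy there gave numbers within the scatter of each other, but hydrogen in place of methyl gave (a 5.1-fold higher number from compound 2 to compound 3 (0.71 log units; beyond the scatter)) and hydrogen in place of methoxy gave (a 9.7-fold higher number from compound 1 to compound 3 (0.99 log units; beyond the scatter)). Among these compounds, both substituted ones therefore stand below the unsubstituted compound 3. Nothing available explains this difference.

The compounds shown leave open whether fluorine, an amine or a longer chain at this carbon would match methyl and methoxy. They also leave open whether hydrogen has a similar effect at other ring carbons.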